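Expected Solubility of a Methyl Amide Analogue

The source may report more compounds than this note shows. Statements on the series, on what has been measured and on what is new or still open speak of the compounds shown alone.

Compound 1 `Cc1cc(/C=C/C#N)cc(C)c1Oc1cc(Nc2ccc(C#N)cc2)c(N)cc1C(=O)OCCC#N` was measured in a physicochemical assay for solubility, read by HPLC, with a stated time of 4 h, at pH 2 (on this read-out lower numbers stand for lower solubility and higher numbers for higher solubility), where compound 1 gives 0.94 ug/mL. Of the two numbers shown so far, this is the lower one. Going by the values given here, the only other measured compound, compound 2 `Cc1cc(/C=C/C#N)cc(C)c1Oc1cc(Nc2ccc(C#N)cc2)c(N)cc1C(N)=O`, gives 2.09 ug/mL in this assay, and the change between them is amino in place of 2-cyanoethoxy on a carbonyl carbon.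

Compound 3 `CNC(=O)c1cc(N)c(Nc2ccc(C#N)cc2)cc1Oc1c(C)cc(/C=C/C#N)cc1C` has not yet been measured. Compared with compound 1 it shows the following difference: methylamino in place of 2-cyanoethoxy on a carbonyl carbon. Among the compounds with values here, the closest parallel among the measured steps is the one to compound 2, since it also replaces the same 2-cyanoethoxy group with a nitrogen-bearing group on the carbonyl carbon, and that step was a 2.2-fold higher number from compound 1 to compound 2 (0.35 log units; beyond the scatter), a modest rise lying beyond the scatter. Within the data shown here, for compound 3 a rise of similar, modest size is therefore expected, a 1.9-fold higher number from compound 1 to compound 3 (0.28 log units; within the scatter), though with only one comparable step the direction is more secure than the exact size. On this basis compound 3 is expected to give about 1.8 ug/mL in this assay, with a range from 0.7 ug/mL to 4.5 ug/mL.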

Compound 3, solubility: 44.7 ug/mL
Estimate against measurement, compound 3: 25-fold (1.40 log units) below, outside the stated range (above it).
By their numbers in this assay, from the lowest: compound 1; then compound 2; then compound 3.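

Placing methylamino instead of 2-cyanoethoxy on the carbonyl carbon gives a 48-fold higher number from compound 1 to compound 3 (1.68 log units; beyond the scatter) in this assay and shows that this position can shift the read-out far more than the first two compounds alone revealed. The closest comparison is more striking: methyl in place of hydrogen on the amide-type nitrogen, a very small structural edit, gives a 21-fold higher number from compound 2 to compound 3 (1.33 log units; beyond the scatter) and accounts for most of the rise, so removing 2-cyanoethoxy is not the whole story. Nothing available here explains why so small a change is followed by so large a difference.

Still open, from the compounds shown here alone, is whether the rise is particular to methyl: an ethyl group or a longer chain on the same nitrogen, a dimethylamino group with no amide hydrogen left, or a cyclic amine such as morpholine on the carbonyl carbon could show whether the number climbs further, holds or falls back. Also open, going by these compounds, is whether compound 1, compound 2 and compound 3 keep the same order in any solubility read-out at another pH.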